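Swapping the sulfonyl aryl group in a hydrazide series

The compounds below may be only part of what the source reports. "The series", "measured", "known", "first", "only" and "open" are said of these compounds alone.

Compound 1, `CC(=O)Nc1ccc(S(=O)(=O)NNC(=O)c2cccnc2Nc2ccc(Cl)cc2)cc1`, was tested in a functional assay on 786-0 cells (Homo sapiens) for antiproliferative activity; a higher number here means a weaker inhibitor of growth, a lower number a stronger inhibitor of growth. In this assay compound 1 gives only a limit, > 100000 nM, and not a number; this is the limit of > 100000 nM in this assay, at which 1 of the 2 values shown sits. A second member of the series, compound 2, `O=C(NNS(=O)(=O)c1ccc(F)cc1)c1cccnc1Nc1ccc(Cl)cc1Cl`, does give a number, and in this assay compound 2 shows 53700 nM. Among the measured compounds shown here, no step between two measured compounds differing in one place is available. The new compound 3, `O=C(NNS(=O)(=O)c1ccc(Cl)cc1Cl)c1cccnc1Nc1ccc(Cl)cc1`, differs from compound 1 by 2,4-dichlorophenyl in place of 4-acetamidophenyl on a sulfonyl sulfur. Since compound 1 sits at a limit, the size of the step can only be guessed; a move toward stronger growth inhibition of about an at least 1.6-fold lower number from compound 1 to compound 3 (0.22 log units; that floor lies within the scatter) is expected, which may not clearly exceed the usual scatter. For compound 3 in this assay a value of 60000 nM is estimated, within a range of 20000 nM to 200000 nM.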

Compound 3, concentration for total growth inhibition: 49000 nM
Compound 3: the middle estimate sits 1.2-fold (0.09 log units) above what was measured; low and high end bracket the measured number.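

Among the compounds shown here, compound 3 provides the first comparison in which only the group on a sulfonyl sulfur changes, and 2,4-dichlorophenyl in place of 4-acetamidophenyl gives an at least 2.0-fold lower number from compound 1 to compound 3 (0.30 log units; that floor lies within the scatter) in this assay. The exchange turns a compound without a measurable end point into one with a number, although the floor of the step does not establish a change beyond the scatter. Compound 1 stands at a limit and not at a number, so the true size of the step remains unknown: the limit of > 100000 nM in this assay, at which 1 of the 3 values shown sits.

The compounds shown do not tell whether either chlorine of the 2,4-dichlorophenyl group matters on its own. They also leave open how an unsubstituted phenyl, a methyl or an aryl group carrying an amine or a carboxylic acid would behave on a sulfonyl sulfur.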